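Urea-to-amide change on the shared core, growth readout

The compounds below may be only part of what the source reports. "The series", "measured", "known", "first", "only" and "open" are said of these compounds alone.

Compound 2 `COc1cc(Cl)cc(-c2nn(-c3cccc(NC(=O)Nc4ccc(Cl)c(C(F)(F)F)c4)c3)cc2-c2ccncc2)c1` and compound 1 `O=C(Nc1cccc(-n2cc(-c3ccncc3)c(-c3cc(O)cc(Cl)c3)n2)c1)Nc1ccc(Cl)c(C(F)(F)F)c1` differ only by methyl in place of hydrogen on an oxygen on an aromatic ring. In a functional assay on NCI-H460 cells (Homo sapiens) for inhibition, read by sulforhodamine B assay, with a stated time of 48 h, tested at 0.01 uM (a lower number here means a stronger effect, a higher number a weaker effect of the compound at the concentration tested), compound 1 gives 101% and compound 2 gives 100%, the step of a number 1 percentage points lower from compound 1 to compound 2 (within the scatter). Compound 2 thus stands on the lowest of the two numbers, yet within the scatter of compound 1, so neither can be ordered against the other.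

Compound 3 `COc1cc(Cl)cc(-c2nn(-c3cccc(NC(=O)c4cccc(C(F)(F)F)c4)c3)cc2-c2ccncc2)c1` is the unmeasured member. Its change from compound 2 is 3-(trifluoromethyl)phenyl in place of (4-chloro-3-(trifluoromethyl)phenyl)amino on a carbonyl carbon. For the measured compounds named here, no measured step touches the carbonyl end of the molecule; the one step seen lies elsewhere and was within the scatter, so it gives no direction for this change. With both measured values near full activity, no step beyond the scatter is expected in this assay, in either direction; the expected step is a number 1 percentage points lower from compound 2 to compound 3 (within the scatter). Compound 3 is therefore estimated at 99%, with a range from 86% to 110%.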

Compound 3, a percentage reported as activity, at one concentration (the size of the read-out at that concentration, not a potency): 101%
Compound 3: the middle estimate sits 2 percentage points below what was measured; the measured number falls inside the stated range.
By their numbers in this assay, from the lowest: compounds 2, 1 and 3 (each within the scatter of the next).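

In this assay, the carbonyl end of the molecule now has a step of its own: a number 1 percentage points higher from compound 2 to compound 3 (within the scatter), with 3-(trifluoromethyl)phenyl in place of (4-chloro-3-(trifluoromethyl)phenyl)amino on a carbonyl carbon. The entering group has no hydrogen-bond donor and the leaving group has one, yet at this single concentration the read-out does not separate the two, so this urea-to-amide exchange adds to the step on the aromatic oxygen as a second one within the scatter. Nothing available here offers an explanation for this result.

Open, on these data alone, is how a methyl or a morpholine group on that carbonyl carbon would read. Also open, as far as these compounds go, is whether compound 1, compound 2 and compound 3 would separate at a higher concentration.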